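Benzyl Ester Step Carried Onto a Second Core

The source may report more compounds than this note shows. Statements on the series, on what has been measured and on what is new or still open speak of the compounds shown alone.

This account concerns three pyrimidinone esters measured in an assay on membranes from HeLa cells for displacement of a labelled ligand from adenosine receptor A3 (Homo sapiens), read by scintillation counting, with a stated time of 180 min, tested at 1 uM (on this read-out lower numbers stand for less inhibition and higher numbers for more inhibition at the one concentration tested (going by the name of the read-out)), and a fourth awaiting measurement. Compound 1 `CC1=C(C(=O)OC(C)(C)C)C(c2ccsc2)NC(=O)N1` gives 1% in this assay. Within the data shown here, compound 2 `CC1=C(C(=O)OCc2ccccc2)C(c2ccsc2)NC(=O)N1` carries the change benzyl in place of tert-butyl on an oxygen next to a carbonyl group and gives 25%; the step of a number 24 percentage points higher from compound 1 to compound 2 (beyond the scatter) is the one recorded comparison within a single core. Compound 3 `CC1=C(C(=O)OC(C)(C)C)C(c2ccoc2)NC(=O)N1C` gives 12% and stands second highest of the three numbers, above compound 1 and below compound 2. How the core of compound 3 differs from that of compound 1 is not broken down here.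

Compound 4 `CC1=C(C(=O)OCc2ccccc2)C(c2ccoc2)NC(=O)N1C` is the not yet measured partner of compound 3, and the change from compound 3 to compound 4 is benzyl in place of tert-butyl on an oxygen next to a carbonyl group, made at a place described in the same words as for the pair of compound 1 and compound 2, so it is the same change, here seen for the second time among these compounds. Among the measured compounds shown here, the expectation for compound 4 rests on a single precedent: since compound 1 moved to compound 2 by a number 24 percentage points higher from compound 1 to compound 2 (beyond the scatter), a rise of comparable size is estimated for the step of a number 21 percentage points higher from compound 3 to compound 4 (beyond the scatter), while the uncertainty stays wide because only one earlier example exists and the cores are not identical. Compound 4 is therefore estimated to give about 33% in this assay, expected to fall between 15% and 52%.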

Compound 4, a percentage reported as inhibition, at one concentration (the size of the read-out at that concentration, not a potency): 25%
For compound 4 the middle estimate is 8 percentage points above the measured one; low and high end bracket the measured number.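

In this assay, benzyl in place of tert-butyl on an oxygen next to a carbonyl group again gives a rise on the second core, a number 13 percentage points higher from compound 3 to compound 4 (beyond the scatter). The change therefore carries from the core of compound 1 to the core of compound 3 in direction, and the two steps cannot be told apart in size: the same change on two cores in this assay, a number 24 percentage points higher (beyond the scatter) from compound 1 to compound 2 and a number 13 percentage points higher (beyond the scatter) from compound 3 to compound 4, 11 percentage points apart, within the scatter of two such steps. Among these compounds, this shows only that the step repeats on two related cores at one tested concentration; it does not show that the step would hold on any further core, and, as these are single-concentration readings, it gives no measure of potency.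

The compounds shown leave open which of the differences between the two cores, if any, bears on the numbers, as no pair separates them from one another. They also leave open how the ester position would respond to anything other than tert-butyl and benzyl, such as a longer chain like n-hexyl, or to replacing the ester with a carboxylic acid or an amide.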